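A few compounds are considered here, and "the series" means these few. Any claim that something is new, unique, unknown or untested is made for them only; others in the source may bear on it.

Three compounds sharing one core were tested in a functional assay (Oryctolagus cuniculus) for inhibition of platelet-activating factor receptor (Cavia porcellus); a lower number here means a stronger inhibitor, a higher number a weaker inhibitor. Compound 1 `CCCC(=O)OCC1CN(C(=O)c2cc(OC)c(OC)c(OC)c2)CCN1C(=O)c1cc(OC)c(OC)c(OC)c1` gives 420 nM. Compound 2 `COc1cc(C(=O)N2CCN(C(=O)c3cc(OC)c(OC)c(OC)c3)C(COC(=O)CC(C)(C)C)C2)cc(OC)c1OC` gives 120 nM. Compound 3 `COc1cc(C(=O)N2CCN(C(=O)c3cc(OC)c(OC)c(OC)c3)C(COC(=O)NCCC(C)C)C2)cc(OC)c1OC` gives 140 nM. Compound 2 stands at the low end of these three numbers: its separation from compound 1 is a 3.5-fold lower number from compound 1 to compound 2 (0.54 log units; beyond the scatter), while its separation from compound 3 is only a 1.2-fold higher number from compound 2 to compound 3 (0.07 log units; within the scatter), a gap within the scatter.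

The fourth compound, compound 4 `CCC(C)CNC(=O)OCC1CN(C(=O)c2cc(OC)c(OC)c(OC)c2)CCN1C(=O)c1cc(OC)c(OC)c(OC)c1`, has not yet been measured in this assay. It differs from compound 2 in one place ((2-methylbutyl)amino in place of neopentyl on a carbonyl carbon). Within the data shown here, the step that bears most directly on this change is the one already seen from compound 2 to compound 3, where isopentylamino took the place of neopentyl on a carbonyl carbon and gave a 1.2-fold higher number from compound 2 to compound 3 (0.07 log units; within the scatter). Among the measured compounds shown here, the change to compound 4 is of the same kind, with (2-methylbutyl)amino entering in place of neopentyl, and the data hold no example of a carbamate branch of this shape behaving differently from the isopentyl one. He therefore expects no step beyond the scatter in this assay, so that compound 4 is estimated at 140 nM, between 60 nM and 330 nM, corresponding to an expected step of a 1.2-fold higher number from compound 2 to compound 4 (0.07 log units; within the scatter).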

Compound 4, half-maximal inhibitory concentration: 470 nM
Compound 4: the middle estimate sits 3.4-fold (0.53 log units) below what was measured; measured number above the stated range.
By their numbers in this assay, from the lowest: compounds 2 and 3 (each within the scatter of the next); then compounds 1 and 4 (each within the scatter of the next).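

In this assay, with the carbamate link the same in both compounds, sec-butyl in place of isobutyl on a saturated chain carbon bound to an amide-type nitrogen gives a 3.4-fold higher number from compound 3 to compound 4 (0.53 log units; beyond the scatter), so the number at this position follows where the branch sits on the chain and not the link alone. Set against the neopentyl ester, (2-methylbutyl)amino on the same carbonyl carbon gives a 3.9-fold higher number from compound 2 to compound 4 (0.59 log units; beyond the scatter), whereas isopentylamino had stayed within the scatter there, so replacing neopentyl with an amino chain has no single outcome at this place. In place of propyl on a carbonyl carbon, (2-methylbutyl)amino gives a 1.1-fold higher number from compound 1 to compound 4 (0.05 log units; within the scatter), so the drop in the number seen with the neopentyl and isopentylamino compounds does not appear with this chain.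

Nothing available here accounts for this dependence on the branch. Going by these compounds, it remains open how a straight pentylamino chain or a neopentylamino group would read at this carbonyl carbon, and whether a 2-methylbutyl chain joined as an ester would follow the carbamate.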